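This account rests on a few compounds, and the source may have more. Where it says the series, first, only, none or still open, it means among the compounds named here.

Measured compounds:
Compound 1, `O=C(/C=C\Nc1ccc(C(F)(F)F)cc1)c1cn(-c2ccccc2)nc1-c1ccc(F)cc1`: > 50000 nM in a functional assay on U-87MG ATCC cells (Homo sapiens) for antiproliferative activity, read by MTT assay, with a stated time of 48 h; on this read-out higher numbers stand for weaker inhibition and lower numbers for stronger inhibition
Compound 2, `COc1ccc(-c2nn(-c3ccccc3)cc2C(=O)/C=C\Nc2ccc(F)cc2)cc1`: 8910 nM

Compound 1 is reported in this assay only as a limit, > 50000 nM, not as a number. Within the data shown here, compound 2 gives 8910 nM, which is the only real number among the two values shown; the other value sits at the limit of > 50000 nM in this assay, at which 1 of the 2 values shown sits. Among the measured compounds shown here, since compound 1 and compound 2 differ in two places at once, no single step can be read between them, and their two values show only that one compound reaches a number and the other does not.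

Compound 3, `COc1ccc(-c2nn(-c3ccccc3)cc2C(=O)/C=C\Nc2ccc(C(F)(F)F)cc2)cc1`, has not yet been measured in this assay. It differs from compound 2 in one place: trifluoromethyl in place of fluoro on an aromatic carbon. For the measured compounds named here, there is no measured pair for this change, so its size can only be guessed. Given that compound 1, which also carries the trifluoromethyl-bearing anilino group, reaches only > 50000 nM, a shift toward weaker inhibition beyond the scatter is expected for compound 3, though the second difference between compounds 1 and 2 leaves this uncertain. Compound 3 is estimated at 25000 nM, with a range of 8000 nM to 80000 nM, meaning an expected step of a 2.8-fold higher number from compound 2 to compound 3 (0.45 log units; beyond the scatter).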

Compound 3, half-maximal inhibitory concentration: > 50000 nM
Compound 3 ended at the assay's limit (the forecaster's own chance of this, stated with the estimate: 35%); at least 2.0-fold (0.30 log units) between middle value and limit.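

With the methoxy-bearing core held constant, trifluoromethyl in place of fluoro on the anilino ring now has a measured effect in this assay: the change gives an at least 5.6-fold higher number from compound 2 to compound 3 (0.74 log units; beyond the scatter). This is a lower bound, not a full measure of the loss. Compound 3 is reported only as a limit of the assay (> 50000 nM), so the true step could be larger. Compound 1 and compound 3 differ in one place, methoxy in place of fluoro on an aromatic carbon, but the step between them cannot be read, and both trifluoromethyl compounds share a single reading: (the limit of > 50000 nM in this assay, at which 2 of the 3 values shown sit).

The compounds shown do not reveal whether that swap of fluoro for methoxy matters at all once trifluoromethyl is present, since any difference between compound 1 and compound 3 is hidden at the limit. They also leave open what other groups would do at the position para to the large group, such as a plain hydrogen, a chlorine atom, a nitrile or an amine, and whether any of these would give a lower number than fluoro.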